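This account rests on a few compounds, and the source may have more. Where it says the series, first, only, none or still open, it means among the compounds named here.

Measured so far:
Compound 1 `Fc1ccc(CSc2nnc(-c3cnccn3)s2)c(F)c1`: 20900 nM
Compound 2 `Clc1ccccc1CSc1nnc(-c2cnccn2)n1-c1ccccc1`: > 50000 nM

In a functional assay on HeLa cells (Homo sapiens) for antiproliferative activity, read by MTT assay, with a stated time of 48 h (a lower number here means a stronger inhibitor, a higher number a weaker inhibitor), compound 1 gives 20900 nM. For compound 2 the assay returns no number, only a limit, so compound 2 sits at the limit of > 50000 nM in this assay, at which 1 of the 2 values shown sits, and its true potency is not pinned down. Compound 3 `c1ccc(CSc2nnc(-c3cnccn3)n2-c2ccccc2)cc1` differs from compound 2 in one place: hydrogen in place of chloro on an aromatic carbon. For the measured compounds named here, no measured pair shows what this change does here, so the step from compound 2 to compound 3 is expected to stay within the scatter, with a number no higher from compound 2 to compound 3 (the limit leaves the size open) as the estimate. Compound 3 is therefore expected near 50000 nM, in the range 20000 nM to 150000 nM, most likely again reported only as a limit.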

Compound 3, half-maximal inhibitory concentration: 35600 nM
Beside the measured number, compound 3's estimate is 1.4-fold (0.15 log units) above it, within the range that was stated.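

In this assay, the change from 2-chlorobenzyl to benzyl gives an at least 1.4-fold lower number from compound 2 to compound 3 (0.14 log units; that floor lies within the scatter). Compound 3 gives 35600 nM, so the benzyl member of this pair has a measured number, and the chloro is not needed for a readable value. The true size of the step stays open because compound 2 has only a limit: the limit of > 50000 nM in this assay, at which 1 of the 3 values shown sits.

On these data alone, what a methoxy, an amine or a carboxylic acid on this aromatic carbon would do remains open. Compound 1 differs from both compounds in more than one place, so it cannot show how this change behaves elsewhere in the series.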